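Taking the Methoxy Group off Compound 2

This account rests on a few compounds, and the source may have more. Where it says the series, first, only, none or still open, it means among the compounds named here.

In a functional assay on MDA-MB-231 cells (Homo sapiens) for cytotoxicity, with a stated time of 48 h (on this read-out higher numbers stand for weaker inhibition and lower numbers for stronger inhibition), compound 1 `COc1cc(OC)c(C(=O)/C=C/c2ccccc2OC)c(OC)c1` gives 13000 nM and compound 2 `COc1cccc(/C=C/C(=O)c2c(OC)cc(OC)cc2OC)c1` gives 8700 nM. These two numbers lie within the usual scatter of each other, so neither compound stands apart. Compound 3 `COc1cc(OC)c(C(=O)/C=C/c2ccccc2)c(OC)c1` has not been measured yet. It differs from compound 2 by one change: hydrogen in place of methoxy on an aromatic carbon. In words, hydrogen sits in place of methoxy on an aromatic carbon. Within the data shown here, only one measured step bears on this, the swap of 2-methoxyphenyl for 3-methoxyphenyl: a 1.5-fold lower number from compound 1 to compound 2 (0.17 log units; within the scatter). Among the measured compounds shown here, that step stayed small, but it keeps the methoxy group, and no measured step removes it, so the guidance is limited. No step beyond the scatter is therefore expected in this assay, in either direction. The estimated step is a 1.1-fold higher number from compound 2 to compound 3 (0.06 log units; within the scatter). The expected value for compound 3 is 10000 nM, within an estimated range of 4000 nM to 25000 nM.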

Compound 3, half-maximal inhibitory concentration: 12900 nM
For compound 3 the middle estimate is 1.3-fold (0.11 log units) below the measured one; measured number inside the range.
By their numbers in this assay, from the lowest: compounds 2, 3 and 1 (each within the scatter of the next).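

In this assay, removing the methoxy group altogether, rather than moving it, gives a 1.5-fold higher number from compound 2 to compound 3 (0.17 log units; within the scatter), and removing it from the 2-methoxyphenyl form gives a 1.0-fold lower number from compound 1 to compound 3 (0.00 log units; within the scatter). The 2-methoxyphenyl, 3-methoxyphenyl and plain phenyl forms therefore cannot be told apart on this read-out, so the methoxy group on this ring, at either of these two places, makes no difference beyond the scatter. No measurement is available here that could explain this result.

As far as these compounds go, it remains open whether a different group on this ring, such as an amine, a carboxylic acid or a fluorine atom, would shift the number beyond the scatter. From the compounds shown here alone, the other methoxy groups stay the same in all three compounds, so their contribution also remains open.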